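Triazole aryl exchange on a weakly antiproliferative spiro series

The compounds below may be only part of what the source reports. "The series", "measured", "known", "first", "only" and "open" are said of these compounds alone.

Going by the values given here, compound 3 `N#CC1=C(N)Oc2c(N)cc3nc4ccccc4nc3c2C12C(=O)N(Cc1cnnn1-c1ccccc1Cl)c1ccccc12` is the only member of the series that returns a number in a functional assay on A549 cells (Homo sapiens) for antiproliferative activity, read by MTT assay, with a stated time of 48 h; on this read-out higher numbers stand for weaker inhibition and lower numbers for stronger inhibition: compound 3 gives 29800 nM. Compound 1 `COc1ccc(-n2nncc2CN2C(=O)C3(C(C#N)=C(N)Oc4c3c3nc5ccccc5nc3c3ccccc43)c3ccccc32)cc1` reaches only the assay limit, > 50000 nM. Compound 2 `N#CC1=C(N)Oc2c(c3nc4ccccc4nc3c3ccccc23)C12C(=O)N(Cc1cnnn1-c1ccc(F)c(Cl)c1)c1ccccc12` likewise reaches only the assay limit, > 50000 nM. Among the compounds with values here, the single one-place step among the measured compounds, a step that the two limits leave unreadable from compound 1 to compound 2, cannot be sized because both ends sit at the limit of > 50000 nM in this assay, at which 2 of the 3 values shown sit. Compound 4 `CCc1cccc(C)c1-n1nncc1CN1C(=O)C2(C(C#N)=C(N)Oc3c(N)cc4nc5ccccc5nc4c32)c2ccccc21` differs from compound 3 by 2-ethyl-6-methylphenyl in place of 2-chlorophenyl on an aromatic nitrogen. Within the data shown here, no measured step bears on this change of the group on an aromatic nitrogen, so no direction can be read from the series. Compound 4 is therefore expected near compound 3, at 30000 nM with a range of 8000 nM to 100000 nM, an expected step of a 1.0-fold higher number from compound 3 to compound 4 (0.00 log units; within the scatter) not beyond the scatter; a limit reading remains quite possible.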

Compound 4, half-maximal inhibitory concentration: > 50000 nM
Compound 4: a limit, no number; the forecaster's own chance of this, stated with the estimate: 45%; middle value at least 1.6-fold (0.22 log units) away from the limit.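

Going by these compounds alone, on an aromatic nitrogen, 2-ethyl-6-methylphenyl in place of 2-chlorophenyl gives an at least 1.6-fold higher number from compound 3 to compound 4 (0.22 log units; that floor lies within the scatter), the first step at this position with a readable floor, though its true size remains unknown. In this assay compound 4 gives only a limit, not a number: the limit of > 50000 nM in this assay, at which 3 of the 4 values shown sit. Within the data shown here, compound 3 therefore remains the only compound here with a number, and this exchange does not improve on it.

Going by these compounds, what 2-methylphenyl or unsubstituted phenyl would give on the core of compound 3 remains open. So does the effect of an amine or a carboxylic acid on that phenyl ring.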